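Swapping the amine substituent: from bicyclic ether to cyano-hydroxypyrrolidine

The source may hold more compounds than are shown below. What is called first, only, known or untested is meant among the compounds shown, and "the series" means these compounds.

Measured so far:
compound 1, `Nc1ncnc2nc(-c3ccc(N4CCC5(CC4)COCO5)nc3)cc(-c3cccc(Br)c3)c12`, 2 umol/kg
compound 2, `Nc1ncnc2nc(-c3ccc(N4CC5CC4CO5)nc3)cc(-c3cccc(Br)c3)c12`, 2 umol/kg

Both compounds share one core and differ only in the ring system carried on the aminopyridine. In a functional assay on the whole organism with Rattus norvegicus as the target (a lower number here means that less compound is needed, a higher number that more compound is needed for the effect), compound 2 gives 2 umol/kg, level with compound 1 within the usual scatter, so neither can be called more potent. Among the compounds with values here, the one step seen so far, no change at the digits printed from compound 1 to compound 2 (within the scatter), shows that exchanging one saturated ring system for another at this spot left the read-out unchanged.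

Compound 3, `N#C[C@H]1CN(c2ccc(-c3cc(-c4cccc(Br)c4)c4c(N)ncnc4n3)cn2)C[C@H]1O`, is not yet measured. It differs from compound 2 by a group of 8 heavy atoms (5 carbon, 2 nitrogen, 1 oxygen; one five-membered non-aromatic ring with 1 hetero atom) in place of a group of 7 heavy atoms (5 carbon, 1 nitrogen, 1 oxygen; 2 five-membered non-aromatic rings with 1 hetero atom each), on an aromatic carbon. This is again an exchange of the saturated group on the same aromatic carbon of a six-membered aromatic ring with 1 nitrogen. Because the earlier exchange gave no change at the digits printed from compound 1 to compound 2 (within the scatter), the expectation for compound 3 in this assay is a step of no change at the digits printed from compound 2 to compound 3 (within the scatter), that is none beyond the scatter. Compound 3 is therefore estimated at 2 umol/kg, with a range from 0.7 umol/kg to 6 umol/kg.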

Compound 3, dose for half-maximal effect: 4 umol/kg
Compound 3: the middle estimate sits 2.0-fold (0.30 log units) below what was measured; the measured number falls inside the stated range.
By their numbers in this assay, from the lowest: compounds 1, 2 and 3 (each within the scatter of the next).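

In this assay, within the data shown here, replacing the two-ring groups of the earlier compounds with a single 3-cyano-4-hydroxypyrrolidin-1-yl ring gives a 2.0-fold higher number from compound 2 to compound 3 (0.30 log units; within the scatter), and the comparison with the larger group gives a 2.0-fold higher number from compound 1 to compound 3 (0.30 log units; within the scatter). This position on the pyridine ring has therefore now held a group with a nitrile, a hydrogen-bond donor and defined stereocentres, with the read-out still inside the scatter of the two-ring groups. No measured evidence is available to explain this result.

All three groups shown are saturated rings, so it remains open whether a simple open-chain amine or a carboxylic acid at this position would also stay within the scatter. Going by these compounds, it also remains open whether the opposite arrangement at the two stereocentres of the 3-cyano-4-hydroxypyrrolidin-1-yl group would give the same read-out.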